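The source may hold more compounds than are shown below. What is called first, only, known or untested is meant among the compounds shown, and "the series" means these compounds.

Of the two compounds measured in a functional assay with sulfonylurea receptor 1, Kir6.2 (Homo sapiens) as the target (a lower number here means that less compound is needed, a higher number that more compound is needed for the effect), compound 2 `O=S1(=O)N=C(NC2CCC2)Nc2ccccc21` has the lowest value, giving 2000 nM. The other compound, compound 1 `Nc1ccc2c(c1)S(=O)(=O)NC(NC1CCC1)=N2`, gives 31600 nM in this assay, a number that is considerably higher than that of compound 2 and lies beyond the usual scatter. Compound 3 `O=S1(=O)N=C(NC2CCC2)Nc2ccc(Cl)cc21` has not been measured yet; it differs from compound 2 by chloro in place of hydrogen on an aromatic carbon. No measured pair of compounds shows the effect of this exact change, so its size has to be estimated from the two compounds shown. The step from compound 2 to compound 3 is expected to go toward a lower number, by a 4.0-fold lower number from compound 2 to compound 3 (0.60 log units; beyond the scatter), a step of moderate size that should exceed the scatter. Compound 3 is estimated to give 500 nM in this assay, with a range from 150 nM to 2000 nM.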

Compound 3, half-maximal effective concentration: 200 nM
Estimate against measurement, compound 3: 2.5-fold (0.40 log units) above; the measured number falls inside the stated range.
By their numbers in this assay, from the lowest: compound 3; then compound 2; then compound 1.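

In this assay, chloro in place of hydrogen on this aromatic carbon gives a 10-fold lower number from compound 2 to compound 3 (1.00 log units; beyond the scatter), the first step shown at this place, so this carbon of the six-membered aromatic ring accepts a substituent and the number responds to it. The entering group is a single chlorine atom with no hydrogen-bond donors or acceptors and no net charge, yet the step lies beyond the scatter. Nothing available here accounts for the size of this step.

From the compounds shown here alone, whether chloro is special at this carbon remains open, since a fluoro, bromo, methyl or methoxy group there would show how far the step depends on the group itself. Also open, going by these compounds, is whether the same step would hold if a longer alkyl chain replaced the cyclobutyl group on the shared core.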